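Benzamide ring swap: fluorophenyl to dichlorophenyl on a shared core

This account rests on a few compounds, and the source may have more. Where it says the series, first, only, none or still open, it means among the compounds named here.

Compound 1 `CCCS(=O)(=O)N1CC2CCC(NC(=O)c3ccc(Cl)cc3Cl)C2C1` gives > 10000 nM in an assay on isolated protein for inhibition of sodium- and chloride-dependent glycine transporter 1 (Homo sapiens) (on this read-out lower numbers stand for stronger inhibition and higher numbers for weaker inhibition), a limit of the assay.
Compound 2 `Cn1cnc(S(=O)(=O)N2CC3CCC(NC(=O)c4ccccc4F)C3C2)c1` gives 1820000 nM in this assay.
Compound 3 `Cn1cnc(S(=O)(=O)N2CC3CCC(NC(=O)c4cccc(F)c4)C3C2)c1` gives > 10000000 nM in this assay, a limit of the assay.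

Compound 3 thus stands at a limit, the weakest end of what is shown. Compound 4 `Cn1cnc(S(=O)(=O)N2CC3CCC(NC(=O)c4ccc(Cl)c(Cl)c4)C3C2)c1` carries 3,4-dichlorophenyl in place of 3-fluorophenyl on a carbonyl carbon. Going by the values given here, no measured step changes the same ring in the same way. Among the compounds with values here, the only step on this ring, an at least 5.4-fold higher number from compound 2 to compound 3 (0.73 log units; beyond the scatter), shows that moving a single fluorine alters the number. Compound 1, with a dichlorophenyl on a different core, sits at a limit as well. The expectation for compound 4 is therefore a number near the weak end, estimated at 3000000 nM ranging from 300000 nM to 20000000 nM, which means an expected step of an at least 3.3-fold lower number from compound 3 to compound 4 (0.52 log units; beyond the scatter).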

Compound 4, half-maximal inhibitory concentration: 891000 nM
Beside the measured number, compound 4's estimate is 3.4-fold (0.53 log units) above it; the range from low to high includes it.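

Compound 4 is the only dichlorophenyl compound shown on this shared core, and its swap gives an at least 11-fold lower number from compound 3 to compound 4 (1.05 log units; beyond the scatter). From the compounds shown here alone, compound 3 is a limit of the assay, so the true size of that step stays unknown. Against the 2-fluorophenyl ring the change is smaller, with a 2.0-fold lower number from compound 2 to compound 4 (0.31 log units; beyond the scatter), so the 3,4-dichlorophenyl ring gives the lowest number of the three on this core, though inhibition remains weak.

The compounds shown leave open whether a phenyl ring with one chlorine would do the same on this core. They also leave open how a ring carrying an amine or a carboxylic acid would behave on this carbonyl carbon.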